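The source may report more compounds than this note shows. Statements on the series, on what has been measured and on what is new or still open speak of the compounds shown alone.

Measured compounds in the series so far:

- Compound 1 `COC(=O)c1cc(-c2cccc(NC(=O)c3ccc(/C=C/C(=O)c4ccc(C)cc4)cc3)c2)on1` — in an ADME assay on Vero cells (Chlorocebus sabaeus) for cytotoxicity, read by MTT assay, with a stated time of 72 h (a higher number here means that more compound is tolerated, a lower number that less compound is tolerated), compound 1 gives > 80 ug/mL, which is a limit of the assay rather than a number.
- Compound 2 `CCOc1ccc(C(=O)/C=C/c2ccc(C(=O)Nc3cccc(-c4cc(C(=O)OC)no4)c3)cc2)cc1` — in this assay compound 2 gives > 40 ug/mL, also a limit.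
- Compound 3 `COC(=O)c1cc(-c2cccc(NC(=O)c3ccc(/C=C/C(=O)c4ccc(Br)cc4)cc3)c2)on1` — in this assay compound 3 gives > 20 ug/mL, again a limit.

Compound 3 therefore stands only as a limit, and the two other values shown are limits as well (the limit of > 20 ug/mL in this assay, at which 1 of the 3 values shown sits, (the limit of > 40 ug/mL in this assay, at which 1 of the 3 values shown sits), (the limit of > 80 ug/mL in this assay, at which 1 of the 3 values shown sits)). None of the three can be placed against another: the step that the two limits leave unreadable from compound 1 to compound 3 and the step that the two limits leave unreadable from compound 2 to compound 3 cannot be read, and neither can the step that the two limits leave unreadable from compound 1 to compound 2. Nothing in the measured set shows a change at the aryl ketone reaching the cytotoxicity read-out at the concentrations tested.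

The next compound, compound 4 `COC(=O)c1cc(-c2cccc(NC(=O)c3ccc(/C=C/C(=O)c4ccc(F)cc4F)cc3)c2)on1`, differs from compound 3 by 2,4-difluorophenyl in place of 4-bromophenyl on a carbonyl carbon. The measured steps that bear on this are the three aryl-ketone exchanges, all of them unreadable, so no direction can be derived from them. The expectation is a step that the limit leaves unreadable from compound 3 to compound 4, that is, none beyond the scatter, with a high chance that compound 4 is again reported only as a limit. Compound 4 is accordingly estimated at 60 ug/mL, with a range from 20 ug/mL to 200 ug/mL in this assay.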

Compound 4, half-maximal cytotoxic concentration: > 40 ug/mL
Compound 4 gave a limit, no number; the forecaster's own chance of this, stated with the estimate: 75%; the middle value is on the limit's open side.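

In this assay compound 4 gives > 40 ug/mL as a limit and not a number. With compound 1, compound 2 and compound 3 also standing only as limits, none of the steps to compound 4 can be read. The compounds shown leave open where the cytotoxicity of each actually lies, and whether any exchange at the aryl ketone changes it.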